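A Bulkier Aryl Urea on a Shared Core

The compounds below may be only part of what the source reports. "The series", "measured", "known", "first", "only" and "open" are said of these compounds alone.

Compound 1 `C=CS(=O)(=O)N1CCN(c2ncnc3sc(-c4ccc(N5CCN(C)CC5)cc4)cc23)CC1`: 7550 nM
Compound 2 `CCS(=O)(=O)N1CCN(c2ncnc3sc(-c4ccc(N5CCN(C)CC5)cc4)cc23)CC1`: 7330 nM
Compound 3 `CN1CCN(c2ccc(-c3cc4c(N5CCN(C(=O)Nc6ccccc6)CC5)ncnc4s3)cc2)CC1`: 7590 nM

Of the compounds shown here, three built on one shared core have been tested in a functional assay on MDA-MB-231 cells (Homo sapiens) for antiproliferative activity, read by MTT assay, with a stated time of 48 h; on this read-out lower numbers stand for stronger inhibition and higher numbers for weaker inhibition. Compound 1 gives 7550 nM, compound 2 gives 7330 nM, and compound 3 gives 7590 nM. The steps between them are all flat: a 1.0-fold lower number from compound 1 to compound 2 (0.01 log units; within the scatter), a 1.0-fold higher number from compound 1 to compound 3 (0.00 log units; within the scatter) and a 1.0-fold higher number from compound 2 to compound 3 (0.02 log units; within the scatter). Compound 3 thus stands together with the other two, its gaps to each within the scatter, so none of the three can be called stronger or weaker.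

Compound 4 `CC(C)c1cccc(C(C)C)c1NC(=O)N1CCN(c2ncnc3sc(-c4ccc(N5CCN(C)CC5)cc4)cc23)CC1` differs from compound 3 in one place: 2,6-diisopropylphenyl in place of phenyl on an amide-type nitrogen. For the measured compounds named here, no measured step touches that amide-type nitrogen; the measured steps exchange the whole substituent on the ring amine, and each of them was flat. With nothing else to go on, the expected step is a 1.0-fold lower number from compound 3 to compound 4 (0.01 log units; within the scatter), that is, no movement beyond the scatter. Compound 4 is therefore estimated at 7500 nM, within a range from 3000 nM to 20000 nM.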

Compound 4, half-maximal inhibitory concentration: 8430 nM
Estimate against measurement, compound 4: 1.1-fold (0.05 log units) below, and the stated range covers the measured number.
By their numbers in this assay, from the lowest: compounds 2, 1, 3 and 4 (each within the scatter of the next).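

Among the steps shown, this is the only one that changes the group on the amide-type nitrogen itself rather than the whole substituent on the ring amine, and in this assay it is flat, with a 1.1-fold higher number from compound 3 to compound 4 (0.05 log units; within the scatter). The entering 2,6-diisopropylphenyl has 12 heavy atoms against 6 for phenyl, all of them carbon and with no hydrogen-bond donors or acceptors on either group, yet the number does not move beyond the scatter. For this pair, then, a large addition of carbon to the aryl group leaves the read-out unchanged.

As far as these compounds go, it remains open whether an amine or a carboxylic acid on that phenyl ring would shift the number, or whether replacing the ring with a short alkyl chain would. No available evidence explains why this step stays flat.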